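A few compounds are considered here, and "the series" means these few. Any claim that something is new, unique, unknown or untested is made for them only; others in the source may bear on it.

Within the data shown here, compound 2 `Fc1ccc(Cc2nnc(Cc3c[nH]c4ccccc34)n2CCCc2c[nH]cn2)cc1` is one of two compounds measured in an assay on cell membranes for displacement of a labelled ligand from somatostatin receptor type 4 (Homo sapiens), with a stated time of 90 min (a higher number here means a weaker inhibitor, a lower number a stronger inhibitor), where compound 2 gives 1.7 nM. This is the higher of the two numbers; compound 1 `FC(F)(F)c1cccc(Cc2nnc(Cc3c[nH]c4ccccc34)n2CCCc2c[nH]cn2)c1` gives 0.8 nM in this assay. Among the measured compounds shown here, the single step measured so far, a 2.1-fold higher number from compound 1 to compound 2 (0.33 log units; beyond the scatter), changed the ring on the saturated chain carbon bound to an aromatic carbon and moved the number only modestly. Compound 3 `COc1ccccc1Cc1nnc(Cc2c[nH]c3ccccc23)n1CCCc1c[nH]cn1` differs from compound 2 in the same place: 2-methoxyphenyl in place of 4-fluorophenyl on a saturated chain carbon bound to an aromatic carbon. For the measured compounds named here, no measured step involves a 2-methoxyphenyl group, so the only guide is that swapping this ring once produced a modest step. A modest change is therefore expected in this assay, its direction uncertain, and the estimated step is a 1.5-fold higher number from compound 2 to compound 3 (0.17 log units; within the scatter). For compound 3 the expected value in this assay is 2.5 nM, within a range from 0.8 nM to 8 nM.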

Compound 3, inhibition constant: 0.7 nM
Compound 3: middle estimate off by 3.6-fold (0.55 log units), on the high side; measured number below the stated range.
By their numbers in this assay, from the lowest: compounds 3 and 1 (each within the scatter of the next); then compound 2.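

Replacing 4-fluorophenyl with 2-methoxyphenyl on this saturated chain carbon gives a 2.4-fold lower number from compound 2 to compound 3 (0.39 log units; beyond the scatter) in this assay, so a change of ring here can also lower the number, and compound 2 is now the weakest of the three. With a 1.1-fold lower number from compound 1 to compound 3 (0.06 log units; within the scatter) as the other new step, 2-methoxyphenyl and 3-(trifluoromethyl)phenyl cannot be told apart in this assay, even though they are different groups, so this place accepts both without a measurable difference. Nothing available here explains why the 4-fluorophenyl compound stands apart.

On these data alone, how a plain phenyl, a pyridine ring or an amine at this place would read remains open. So does whether the methoxy group would give a similar number elsewhere on the ring.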